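Removing a fluorine from a weak calcium channel inhibitor

The source may report more compounds than this note shows. Statements on the series, on what has been measured and on what is new or still open speak of the compounds shown alone.

Compound 2 `NCCCOc1ccc(CNc2nc3ccc(Oc4ccc(F)cc4)cc3s2)cc1` gives 106000 nM in an assay on SH-SY5Y cells for inhibition of Voltage-dependent N-type calcium channel subunit alpha-1B (Homo sapiens), read by FLIPR and calcium flux, with stated times of 600 s and 300 s, in the presence of a further agent that is not named here (a higher number here means a weaker inhibitor, a lower number a stronger inhibitor), the highest of the two numbers available; compound 1 `CN(Cc1ccc(OCCCN)cc1)c1nc2ccc(Oc3ccccc3)cc2s1` gives 49000 nM in this assay, a difference beyond the usual scatter. Compound 3 `NCCCOc1ccc(CNc2nc3ccc(Oc4ccccc4)cc3s2)cc1` differs from compound 2 by hydrogen in place of fluoro on an aromatic carbon. Among the compounds with values here, no measured pair shows this exact change, so the step from compound 2 to compound 3 is expected to be small, likely toward a lower number but not clearly beyond the scatter, a 1.5-fold lower number from compound 2 to compound 3 (0.18 log units; within the scatter). Compound 3 is therefore estimated at 70000 nM, within a range from 30000 nM to 160000 nM.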

Compound 3, half-maximal inhibitory concentration: 218000 nM
Estimate against measurement, compound 3: 3.1-fold (0.49 log units) below, outside the stated range (above it).
By their numbers in this assay, from the lowest: compound 1; then compound 2; then compound 3.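

Going from 4-fluorophenoxy to phenoxy does not lower the number but gives a 2.1-fold higher number from compound 2 to compound 3 (0.31 log units; beyond the scatter), so at this place the fluoro compound is the stronger inhibitor of the pair. The methyl on the nitrogen matters as well: replacing it with hydrogen gives a 4.4-fold higher number from compound 1 to compound 3 (0.65 log units; beyond the scatter), which leaves compound 3 the weakest of the three. Nothing measured here explains either step.

On these data alone, whether a chlorine atom or a methoxy group at the fluorine's place would lower the number further remains open. So does whether the fluorine and the nitrogen methyl would together give a stronger inhibitor.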